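Isothiazole ester in place of methylthiazole on the short-lived epimer

A few compounds are considered here, and "the series" means these few. Any claim that something is new, unique, unknown or untested is made for them only; others in the source may bear on it.

Compound 1 `COC(=O)CCNC(=O)[C@@H]1O[P@](=O)(OCOC(=O)c2scnc2C)OCC1(C)C` stands at the lower end of the three numbers in hand: in an ADME assay on blood (Homo sapiens) for pharmacokinetics (on this read-out higher numbers stand for a longer-lived compound and lower numbers for a shorter-lived compound), compound 1 gives a limit of the assay, < 0.16 h, and not a number. Compound 2 `COC(=O)CCNC(=O)[C@@H]1O[P@@](=O)(OCOC(=O)c2scnc2C)OCC1(C)C` differs only in the configuration drawn at phosphorus; in this assay compound 2 also returns a limit, > 1 h. The step of an at least 6.2-fold higher number from compound 1 to compound 2 (0.79 log units; beyond the scatter) is therefore readable only as a lower bound. Compound 3 `CCc1cc(C(=O)OCO[P@@]2(=O)OCC(C)(C)[C@H](C(=O)NCCC(=O)OC)O2)n(C)n1` carries a different ester, and in this assay compound 3 gives >= 0.97 h, again a limit; the step that the two limits leave unreadable from compound 2 to compound 3 cannot be sized.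

Compound 4 `COC(=O)CCNC(=O)[C@@H]1O[P@](=O)(OCOC(=O)c2ccns2)OCC1(C)C` keeps the configuration of compound 1 and changes the ester: 1,2-thiazol-5-yl in place of 4-methyl-1,3-thiazol-5-yl on a carbonyl carbon. Going by the values given here, no measured step addresses an ester swap on this configuration, since the only readable step concerns configuration. Compound 4 is therefore expected to stay close to compound 1, with the step that the limit leaves unreadable from compound 1 to compound 4 estimated as small, and its half-life is estimated at 0.15 h within 0.05 h to 0.5 h.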

Compound 4, half-life: < 0.16 h
Compound 4: no number, only a limit; the forecaster's own chance of this, stated with the estimate: 60%; the middle value lies beyond the limit too.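

In this assay compound 4 gives < 0.16 h, a limit of the assay and not a number. Going by these compounds alone, compound 1 also stands at a limit, and no step between compound 1 and compound 4 can be read. The compounds shown leave open whether 1,2-thiazol-5-yl and 4-methyl-1,3-thiazol-5-yl differ in half-life on this configuration at phosphorus.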